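Methoxy for nitro on the aromatic ring: compound 4

The source may hold more compounds than are shown below. What is called first, only, known or untested is meant among the compounds shown, and "the series" means these compounds.

Measured so far in a functional assay on LNCaP cells (Homo sapiens) for cytotoxicity, read by MTT assay, with a stated time of 72 h; on this read-out higher numbers stand for weaker inhibition and lower numbers for stronger inhibition:
- compound 1 `COc1cc(/C=C/C(=O)/C=C/C2=C(C)CCCC2(C)C)ccc1O` gives 9500 nM
- compound 2 `CC1=C(/C=C/C(=O)/C=C/c2ccc(O)c([N+](=O)[O-])c2)C(C)(C)CCC1` gives 26800 nM
- compound 3 `CC1=C(/C=C/C(=O)/C=C/c2cccc([N+](=O)[O-])c2)C(C)(C)CCC1O` gives 2000 nM

Compound 3 holds the lowest of the three numbers; the steps to compound 1 and to compound 2 are both beyond the scatter. Compound 2 and compound 3 have the same atoms joined differently; the difference between the two cores is not broken down here.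

The unmeasured compound 4 `COc1cccc(/C=C/C(=O)/C=C/C2=C(C)C(O)CCC2(C)C)c1` is derived from compound 3 by the change (methoxy in place of nitro on an aromatic carbon). The same kind of change carries compound 2 to compound 1, (methoxy in place of nitro on an aromatic carbon), and there it made a step of a 2.8-fold lower number from compound 2 to compound 1 (0.45 log units; beyond the scatter). The two places are not identical: in compound 2 the place is ortho to a hydroxy group (1 heavy atom), in compound 3 it is only meta to a large group, and the two cores differ as noted. Going by the values given here, only this one earlier step is available.

For compound 4 a step of a 2.2-fold lower number from compound 3 to compound 4 (0.35 log units; beyond the scatter) is expected in this assay, resting on the direction of a 2.8-fold lower number from compound 2 to compound 1 (0.45 log units; beyond the scatter). Compound 4 is estimated at 900 nM, between 300 nM and 3000 nM.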

Compound 4, half-maximal inhibitory concentration: 4900 nM
For compound 4 the middle estimate is 5.4-fold (0.74 log units) below the measured one; measured number outside the range, above it.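

In this assay, methoxy in place of nitro on an aromatic carbon gives a 2.5-fold higher number from compound 3 to compound 4 (0.39 log units; beyond the scatter) and so runs against the earlier step on the other core. The change therefore keeps no fixed direction from one core to the other in this series: the same change on two cores in this assay, a 2.8-fold lower number (0.45 log units; beyond the scatter) from compound 2 to compound 1 and a 2.5-fold higher number (0.39 log units; beyond the scatter) from compound 3 to compound 4, 6.9-fold (0.84 log units) apart, beyond the scatter of two such steps. This does not show what separates the two outcomes, as the cores differ and the aromatic ring of compound 2 also carries a hydroxy group, and with a single pair on each core neither direction can stand as the rule for the series.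

The compounds shown leave open whether the hydroxy group on the aromatic ring of compound 2 or the rest of the core decides the direction of the step. They also leave open how an amine or a carboxylic acid on the same aromatic carbon in the core of compound 3 would compare with nitro and methoxy.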